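A few compounds are considered here, and "the series" means these few. Any claim that something is new, unique, unknown or untested is made for them only; others in the source may bear on it.

Measured in a physicochemical assay for lipophilicity, at pH 7.4; a lower number here means a more polar compound, a higher number a more lipophilic compound:
- Compound 1 `C[C@H]1C(=O)N(C)C=Cc2cc(C(CO)CO)ccc21`: 1.2
- Compound 2 `CCOc1ccc2c(c1)C(c1cnn(C)c1)=CN(C)C(=O)[C@@H]2C`: 4.1

Among the compounds with values here, only two compounds have been measured so far. Compound 2 stands higher at 4.1, and compound 1 gives 1.2. The gap between the two lies well beyond the scatter. These two differ in more than one place, so their gap cannot be pinned on any single change.

Compound 3 `C[C@H]1C(=O)N(C)C=C(c2cnn(C)c2)c2cc(C(CO)CO)ccc21` is derived from compound 2 by one change: 2-hydroxy-1-(hydroxymethyl)ethyl in place of ethoxy on an aromatic carbon. Compound 1 carries that same 2-hydroxy-1-(hydroxymethyl)ethyl group and gives 1.2, so compound 3 is expected to land far nearer to compound 1 than to compound 2. Compound 3 also keeps a ring-bearing group that compound 1 lacks. The data do not show what that group contributes, so the range stays wide. The expected change is a large fall in this assay, well beyond the scatter, with an estimated a number 2.50 log units lower from compound 2 to compound 3 (beyond the scatter). For compound 3 the estimate is 1.6, with an expected range from 1 to 2.3.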

Compound 3, distribution coefficient: 1.4
Beside the measured number, compound 3's estimate is 0.20 log units above it; low and high end bracket the measured number.
By their numbers in this assay, from the lowest: compounds 1 and 3 (each within the scatter of the next); then compound 2.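

In this assay, placing 2-hydroxy-1-(hydroxymethyl)ethyl in place of ethoxy on the aromatic carbon gives a number 2.70 log units lower from compound 2 to compound 3 (beyond the scatter), so this single change on its own accounts for a large move, which the earlier pair could not show. The second comparison, with 1-methyl-1H-pyrazol-4-yl in place of hydrogen on a double-bonded ring carbon, gives a number 0.20 log units higher from compound 1 to compound 3 (within the scatter), so with 2-hydroxy-1-(hydroxymethyl)ethyl present, the assay cannot tell compound 1 and compound 3 apart. Taken together, the two steps place nearly all of the gap between compound 1 and compound 2 on the change at the aromatic carbon, although nothing shown here explains why the number moves as it does.

As far as these compounds go, only ethoxy and 2-hydroxy-1-(hydroxymethyl)ethyl are compared at this aromatic carbon, so it remains open where a shorter chain such as hydroxymethyl, an amine or a carboxylic acid would fall on this scale. From the compounds shown here alone, the 1-methyl-1H-pyrazol-4-yl step is also read only with 2-hydroxy-1-(hydroxymethyl)ethyl on the aromatic ring, so its size with ethoxy in that place remains open as well.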